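Halogen Exchange on the Fused Ring of a Urea Series

The compounds below may be only part of what the source reports. "The series", "measured", "known", "first", "only" and "open" are said of these compounds alone.

Measured so far:
compound 1, `CC(C)(C)c1cc(NC(=O)Nc2ccc(-c3cn4ccccc4n3)cc2)no1`: 3.09 nM
compound 2, `CC(C)(C)c1cc(NC(=O)Nc2ccc(-c3cn4cccc(F)c4n3)cc2)no1`: 12.2 nM

Both compounds were tested in a functional assay on MV4-11 cells (Homo sapiens) for cytotoxicity, read by MTT assay, with a stated time of 72 h; a higher number here means a weaker inhibitor, a lower number a stronger inhibitor. Compound 1 gives 3.09 nM and compound 2 gives 12.2 nM. Compound 2 therefore stands at the higher of the two numbers; its nearest neighbour is compound 1, and the step of a 3.9-fold higher number from compound 1 to compound 2 (0.60 log units; beyond the scatter) is beyond the scatter, so compound 2 is the weaker of the pair.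

Compound 3, `CC(C)(C)c1cc(NC(=O)Nc2ccc(-c3cn4cccc(Cl)c4n3)cc2)no1`, has not yet been measured. It differs from compound 2 in one place: chloro in place of fluoro on an aromatic carbon. Among the measured compounds shown here, the only measured step that bears on this position is a 3.9-fold higher number from compound 1 to compound 2 (0.60 log units; beyond the scatter), which shows that putting a substituent there costs some potency. For the measured compounds named here, whether a larger halogen at the same place costs more, the same, or less, no measured pair tells; the scatter of the method also leaves room for no real change.

On that basis, compound 3 is expected to give about 15 nM, within a range from 5 nM to 45 nM, so that the estimated step of a 1.2-fold higher number from compound 2 to compound 3 (0.09 log units; within the scatter) stays close to the scatter.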

Compound 3, half-maximal inhibitory concentration: 353 nM
The estimate for compound 3 lay 24-fold (1.37 log units) below the measured number; the whole stated range lies below it.
By their numbers in this assay, from the lowest: compound 1; then compound 2; then compound 3.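

In this assay, this position proves far more sensitive to the identity of the halogen than the earlier pair could show: a 29-fold higher number from compound 2 to compound 3 (1.46 log units; beyond the scatter) is a large step for the exchange of one heavy atom for another, though neither group brings a ring, a hydrogen-bond donor or acceptor, or a net charge. Measured against hydrogen at the same aromatic carbon, chloro gives a 110-fold higher number from compound 1 to compound 3 (2.06 log units; beyond the scatter), well past the modest 3.9-fold higher number from compound 1 to compound 2 (0.60 log units; beyond the scatter), so among these three compounds the cost of a substituent here depends strongly on which substituent it is and is not one fixed penalty. Nothing available explains why chloro and fluoro part so widely at this carbon.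

These compounds leave open whether the loss continues with bromo or belongs to any group heavier than fluoro, which a methyl or methoxy group or an amine on the same carbon would help to separate. They also leave open whether chloro costs as much on the other carbons of this six-membered aromatic ring, or whether the sensitivity is confined to the carbon two atoms from the ring nitrogen.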